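Swapping bromo for chloro on an indolinone-type scaffold

A few compounds are considered here, and "the series" means these few. Any claim that something is new, unique, unknown or untested is made for them only; others in the source may bear on it.

Measured compounds:
- Compound 1 `COc1ccc(C2=NN(C3=NC(=O)/C(=C4\C(=O)Nc5ccccc54)S3)C(c3ccc(OC)cc3)C2)cc1` — 85200 nM
- Compound 2 `COc1ccc(C2CC(c3ccc4ccccc4c3)=NN2C2=NC(=O)/C(=C3\C(=O)Nc4ccccc43)S2)cc1` — 870 nM
- Compound 3 `COc1ccc(-c2cc(-c3ccc(Cl)cc3)n(C3C(=O)Nc4ccc(Br)cc43)n2)cc1` — 9200 nM

All three were tested in a functional assay on cells (Cancer cell lines, Homo sapiens) for cytotoxicity, read by sulforhodamine B assay, with a stated time of 48 h; on this read-out lower numbers stand for stronger inhibition of growth and higher numbers for weaker inhibition of growth. Compound 3 stands second highest of the three numbers: compound 1 gives a higher number, while compound 2 gives a lower one, and both gaps lie beyond the scatter.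

Compound 4 `COc1ccc(-c2cc(-c3ccc(Cl)cc3)n(C3C(=O)Nc4ccc(Cl)cc43)n2)cc1` has not yet been measured. It differs from compound 3 in one place: chloro in place of bromo on an aromatic carbon. Among the compounds with values here, the only step measured so far, a 98-fold lower number from compound 1 to compound 2 (1.99 log units; beyond the scatter), concerns a different part of a different core, a naphthalen-2-yl entering for 4-methoxyphenyl, and so it does not bear on this change. Within the data shown here, no measured pair tells what a bromo-to-chloro swap does here. With nothing pointing either way, the expected step of no change at the digits printed from compound 3 to compound 4 (within the scatter) is none beyond the scatter. Compound 4 is therefore estimated at 9200 nM, with a range from 4000 nM to 21000 nM.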

Compound 4, concentration for 50% growth inhibition: 3750 nM
The estimate for compound 4 lay 2.5-fold (0.39 log units) above the measured number; measured number below the stated range.
By their numbers in this assay, from the lowest: compound 2; then compound 4; then compound 3; then compound 1.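

The swap of halogen gives a 2.5-fold lower number from compound 3 to compound 4 (0.39 log units; beyond the scatter) in this assay and so shows that this aromatic carbon of the fused system of two rings is sensitive to which halogen it carries. The step is modest, yet it lies beyond the scatter even though only one heavy atom is exchanged for another, with no hydrogen-bond donor, acceptor or net charge entering or leaving. No measurement shown here gives a reason for this step.

As far as these compounds go, with only bromo and chloro compared on this carbon, it remains open what fluoro, a plain hydrogen, a methyl group or an amine would do there. From the compounds shown here alone, it is also open whether the same exchange would have a similar effect on the chlorophenyl ring, or on the core of compound 1.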